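Fluoro in Place of Methoxy on an Aromatic Carbon

The source may hold more compounds than are shown below. What is called first, only, known or untested is meant among the compounds shown, and "the series" means these compounds.

Among the compounds with values here, compound 2 `COc1ccc(/C=C2\S/C(=N\c3nc(-c4ccc(Cl)cc4)cs3)NC2=O)cc1` is one of only two compounds so far measured in a functional assay on HT-29 cells (Homo sapiens) for cytotoxicity, read by MTT assay, with a stated time of 72 h (a lower number here means a stronger inhibitor, a higher number a weaker inhibitor), where compound 2 gives 400 nM. Compound 1 `Cc1ccc(/C=C2\S/C(=N\c3nc(-c4ccc(Cl)cc4)cs3)NC2=O)cc1` carries a methyl where compound 2 carries the methoxy, and in this assay compound 1 gives 500 nM. The step of a 1.3-fold lower number from compound 1 to compound 2 (0.10 log units; within the scatter) lies within the scatter, so the two compounds cannot be placed in any order on these numbers. Compound 3 `O=C1N/C(=N/c2nc(-c3ccc(Cl)cc3)cs2)S/C1=C\c1ccc(F)cc1` has not yet been measured. It differs from compound 2 by fluoro in place of methoxy on an aromatic carbon. Within the data shown here, the single measured step that bears on this change is a 1.3-fold lower number from compound 1 to compound 2 (0.10 log units; within the scatter), which also exchanged the group on this aromatic carbon and moved the number by less than the scatter. A step of about a 1.3-fold higher number from compound 2 to compound 3 (0.10 log units; within the scatter) is therefore expected, nothing beyond the scatter. Compound 3 is estimated to give 500 nM in this assay, with a range from 200 nM to 1250 nM.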

Compound 3, half-maximal inhibitory concentration: 2900 nM
For compound 3 the middle estimate is 5.8-fold (0.76 log units) below the measured one; measured number above the stated range.
By their numbers in this assay, from the lowest: compounds 2 and 1 (each within the scatter of the next); then compound 3.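

In this assay the group on this aromatic carbon now matters, which the exchange of methyl for methoxy could not show: fluoro in place of methoxy gives a 7.3-fold higher number from compound 2 to compound 3 (0.86 log units; beyond the scatter) and fluoro in place of methyl gives a 5.8-fold higher number from compound 1 to compound 3 (0.76 log units; beyond the scatter). Both steps lie beyond the scatter, so compound 3, with its 4-fluorophenyl, is the weakest of the three, while compound 1 and compound 2 remain without an order. Nothing measured here accounts for the gap between fluoro and the other two groups.

The compounds shown leave open whether an amine, a hydroxyl or a longer alkoxy chain on this carbon would stay level with compound 1 and compound 2 or fall toward compound 3. They also leave open whether chloro or bromo here would follow fluoro.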